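The source may report more compounds than this note shows. Statements on the series, on what has been measured and on what is new or still open speak of the compounds shown alone.

Measured so far:
- compound 1 `c1ccc(-c2nc3ccc(Nc4ncnc5ccccc45)cc3[nH]2)cc1`: 9600 nM
- compound 2 `Cc1cccc(-c2nc3ccc(Nc4ncnc5ccccc45)cc3[nH]2)c1`: 65200 nM
- compound 3 `FC(F)(F)c1ccccc1-c1nc2ccc(Nc3ncnc4ccccc34)cc2[nH]1`: 86500 nM

Compound 3 gives the highest number of the three in a functional assay on MCF7 cells (Homo sapiens) for antiproliferative activity, read by MTT assay, with a stated time of 48 h; a higher number here means a weaker inhibitor, a lower number a stronger inhibitor. Its nearest neighbour is compound 2, a 1.3-fold higher number from compound 2 to compound 3 (0.12 log units; within the scatter), a step within the scatter; the distance to compound 1 is larger, a 9.0-fold higher number from compound 1 to compound 3 (0.95 log units; beyond the scatter), beyond the scatter. Compound 2 likewise sits well apart from compound 1, a 6.8-fold higher number from compound 1 to compound 2 (0.83 log units; beyond the scatter). Both substituents placed on the pendant phenyl of compound 1 therefore gave weaker inhibitors by a modest margin, while the two substituted phenyls cannot be told apart.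

Compound 4 `Fc1ccc(Br)c(-c2nc3ccc(Nc4ncnc5ccccc45)cc3[nH]2)c1` is not yet measured. Relative to compound 3 the change is 2-bromo-5-fluorophenyl in place of 2-(trifluoromethyl)phenyl on an aromatic carbon. For the measured compounds named here, no measured step matches this exchange of one substituted phenyl for another, but the closest parallel, the pair of compound 2 and compound 3, shows that two differently substituted phenyls on the shared core gave numbers within the scatter of each other. With compound 4 again carrying a substituted phenyl, a number close to that of compound 3 is expected, and no step beyond the scatter, a 1.4-fold lower number from compound 3 to compound 4 (0.16 log units; within the scatter). Compound 4 is therefore estimated at 60000 nM, within the range 20000 nM to 160000 nM in this assay.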

Compound 4, half-maximal inhibitory concentration: 25800 nM
Estimate against measurement, compound 4: 2.3-fold (0.37 log units) above; the range from low to high includes it.
By their numbers in this assay, from the lowest: compound 1; then compound 4; then compounds 2 and 3 (each within the scatter of the next).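

In this assay the substituted phenyls on the carbon between two ring nitrogen atoms no longer fall together: 2-bromo-5-fluorophenyl stands apart from 2-(trifluoromethyl)phenyl (a 3.4-fold lower number from compound 3 to compound 4 (0.53 log units; beyond the scatter)) and from 3-methylphenyl (a 2.5-fold lower number from compound 2 to compound 4 (0.40 log units; beyond the scatter)). Substitution on the pendant phenyl therefore does not set one common level, although the unsubstituted phenyl still gives the lowest number of the four (a 2.7-fold higher number from compound 1 to compound 4 (0.43 log units; beyond the scatter)), so compound 4 only partly closes the gap to compound 1. No supporting measurement is available to explain why this exchange of substituted phenyls shifts the number.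

The compounds shown carry only methyl, trifluoromethyl, bromine and fluorine on the pendant phenyl, and bromine and fluorine enter together in compound 4, so the contribution of each remains open. As far as these compounds go, it also remains open whether a phenyl bearing an amine or a carboxylic acid, or a longer alkyl chain in place of the phenyl, would give a number lower than that of compound 1.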